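This account rests on a few compounds, and the source may have more. Where it says the series, first, only, none or still open, it means among the compounds named here.

Compound 1 `NC(=O)CC[C@H](NC(=O)CN(c1ncnc2c1ncn2C1CCCCO1)C1CC1)C(=O)OCc1ccccc1` and compound 2 `O=C(O)[C@@H]1CCCN1C(=O)CN(c1nc(Cl)nc2[nH]cnc12)C1CC1` were both tested in a functional assay on the whole organism (Tail, strain ICR) with Mus musculus as the target, in the tail flick test, with a stated time of 30 min, at a dose of 25 umol/kg by the oral route; a lower number here means a weaker effect, a higher number a stronger effect of the compound at the dose given. In this assay compound 1 gives 47%. In this assay compound 2 gives 31.5%. Compound 1 stands highest of the two numbers, and its nearest neighbour, compound 2, lies lower by a gap beyond the usual scatter. Going by the values given here, the two measured compounds differ in several places at once, so no single-change step exists among them. Compound 3 `O=C(CN(c1ncnc2c1ncn2C1CCCCO1)C1CC1)NCC(=O)OCc1ccccc1` has not yet been measured in this assay. It differs from compound 1 in one place: hydrogen in place of 2-carbamoylethyl on a saturated chain carbon bound to an amide-type nitrogen and a carbonyl carbon. Among the compounds with values here, no measured pair shows what such a change does here, so the expectation rests on compound 1 alone. The author expects the step of a number 9 percentage points lower from compound 1 to compound 3 (within the scatter) to be small and towards a weaker effect, possibly not beyond the scatter. Compound 3 is therefore estimated at 38%, within a range from 20% to 55%.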

Compound 3, a percentage reported as activity, at one dose (the size of the read-out at that dose, not a potency): 55.7%
For compound 3 the middle estimate is 17.7 percentage points below the measured one, and the stated range ends below it.
By their numbers in this assay, from the lowest: compound 2; then compounds 1 and 3 (each within the scatter of the next).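

In this assay, going by these compounds alone, hydrogen in place of 2-carbamoylethyl on a saturated chain carbon bound to an amide-type nitrogen and a carbonyl carbon gives a number 8.7 percentage points higher from compound 1 to compound 3 (within the scatter), the first reading of a change at this place. It shows that the effect at this dose does not depend on 2-carbamoylethyl, since the whole group can leave and the number stays within the scatter of compound 1. Nothing available here explains why this group can be lost in this way.

The compounds shown leave open what a methyl group, a longer chain ending in an amine or a carboxylic acid on this same carbon would do in this assay. They also leave open whether the step from 2-carbamoylethyl to hydrogen would stay this small at another dose or time.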